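The source may hold more compounds than are shown below. What is called first, only, known or untested is meant among the compounds shown, and "the series" means these compounds.

Compound 1 `C=C1CC[C@H]2[C@@](C)(CCC(=O)N[C@@]2(C)CO)[C@@H]1/C=C/C1=CCOC1=O` carries a hydroxy group on a saturated carbon in its side chain. In an assay for inhibition of hexokinase-2 (Homo sapiens), read by coupled enzyme assay, with a stated time of 10 min, in the presence of a further agent that is not named here (a lower number here means a stronger inhibitor, a higher number a weaker inhibitor), compound 1 returns only the limit > 50000 nM, which is not a number. Compound 2 `C=C1CC[C@H]2[C@@](C)(CCC(=O)N[C@@]2(C)COC(=O)c2cccnc2)[C@@H]1/C=C/C1=CCOC1=O` differs from compound 1 by (pyridin-3-yl)carbonyl in place of hydrogen on an oxygen on a saturated carbon. In this assay compound 2 likewise returns only the limit > 50000 nM. The step that the two limits leave unreadable from compound 1 to compound 2 is therefore unreadable: both ends sit at the limit, so the size of the change is hidden.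

Compound 3 `C=C1CC[C@H]2[C@@](C)(CC[C@@H](O)[C@@]2(C)NC=O)[C@@H]1/C=C/C1=CCOC1=O` has the same atoms as compound 1 joined differently; the difference between the two cores is not broken down here. In this assay compound 3 gives only the limit > 50000 nM. Compound 4 `C=C1CC[C@H]2[C@@](C)(CC[C@@H](OC(=O)c3cccnc3)[C@@]2(C)NC=O)[C@@H]1/C=C/C1=CCOC1=O` has not been measured; it differs from compound 3 by (pyridin-3-yl)carbonyl in place of hydrogen on an oxygen on a saturated carbon. Going by the values given here, this is the same kind of change as the one from compound 1 to compound 2, but not the same: in compound 1 the oxygen sits on a saturated carbon whose other neighbour is a saturated chain carbon, whereas in compound 3 that neighbour is a saturated ring carbon.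

All three measured values share the limit (the limit of > 50000 nM in this assay, at which 3 of the 3 values shown sit). Compound 4 is expected to give about 80000 nM in this assay, most likely once more only as a limit, within an expected range of 30000 nM to 300000 nM. The expected step that the limit leaves unreadable from compound 3 to compound 4 is essentially flat, resting on the shared limit of > 50000 nM in this assay, at which 3 of the 3 values shown sit, and on the unreadable step that the two limits leave unreadable from compound 1 to compound 2.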

Compound 4, half-maximal inhibitory concentration: > 50000 nM
Compound 4 ended at the assay's limit; the forecaster's own chance of this, stated with the estimate: 85%; the middle value does not contradict the limit.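

No step can be read from compound 3 to compound 4, just as none can be read from compound 1 to compound 2, because all four compounds return a limit rather than a number: the limit of > 50000 nM in this assay, at which 4 of the 4 values shown sit.

The compounds shown leave open whether any of them has a measurable effect in this assay and whether adding (pyridin-3-yl)carbonyl changes that effect at all.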